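Amide aryl variation on the shared core

The source may report more compounds than this note shows. Statements on the series, on what has been measured and on what is new or still open speak of the compounds shown alone.

Within the data shown here, compound 2 `CN(C)C(=O)c1cc2cnc(Nc3ccc(NC(=O)C4(C(=O)Nc5cccc(Br)c5)CC4)cc3)nc2n1C1CCCC1` holds the highest of the three numbers so far in a functional assay on T47D cells (Homo sapiens) for inhibition, read by CCK-8 assay, with a stated time of 72 h, tested at 1 uM (a higher number here means more inhibition of growth at the concentration tested, a lower number less inhibition of growth), giving 29.1%. Compound 1 `CN(C)C(=O)c1cc2cnc(Nc3ccc(NC(=O)C4(C(=O)Nc5cccc(C(F)(F)F)c5)CC4)cc3)nc2n1C1CCCC1` gives 9.7%, and compound 3 `CN(C)C(=O)c1cc2cnc(Nc3ccc(N)cn3)nc2n1C1CCCC1` gives 18.8%. Among the measured compounds shown here, the only measured step that bears on the next change is a number 19.4 percentage points higher from compound 1 to compound 2 (beyond the scatter), where a single group on an aromatic carbon was exchanged. Compound 4 `COc1ccc(NC(=O)C2(C(=O)Nc3ccc(Nc4ncc5cc(C(=O)N(C)C)n(C6CCCC6)c5n4)cc3)CC2)cc1` differs from compound 2 by 4-methoxyphenyl in place of 3-bromophenyl on an amide-type nitrogen. As this again replaces one substituted phenyl by another, a step of comparable size is plausible, but with a single pair the direction cannot be read, and compound 3 offers no guidance on this position. Compound 4 is expected to give 18%, with a range from 5% to 35%. The step of a number 11.1 percentage points lower from compound 2 to compound 4 (beyond the scatter) is expected to be modest and downward.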

Compound 4, percent growth inhibition at one concentration: 76.4%
Beside the measured number, compound 4's estimate is 58.4 percentage points below it; the measured number lies above the stated range.
By their numbers in this assay, from the lowest: compounds 1 and 3 (each within the scatter of the next); then compound 2; then compound 4.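

With 4-methoxyphenyl on the amide-type nitrogen, this assay shows a number 47.3 percentage points higher from compound 2 to compound 4 (beyond the scatter) and a number 66.7 percentage points higher from compound 1 to compound 4 (beyond the scatter) when 3-(trifluoromethyl)phenyl is the group replaced. This aryl group can therefore swing the growth inhibition far more than the earlier exchange of one group on the ring indicated. No measurement at hand accounts for the gain.

The group and its ring position changed together, and the compounds shown do not separate the two. 3-Methoxyphenyl and 4-bromophenyl would divide these effects, while 4-hydroxyphenyl or 4-ethoxyphenyl would test how specific the methoxy group is.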